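From a carboxy limit back to an amino group

The source may hold more compounds than are shown below. What is called first, only, known or untested is meant among the compounds shown, and "the series" means these compounds.

In a functional assay on SK-OV-3 cells (Homo sapiens) for inhibition, read by CCK-8 assay, with a stated time of 70 h (on this read-out lower numbers stand for stronger inhibition and higher numbers for weaker inhibition), compound 2 (`O=C(O)c1ccccc1COc1ccc(OCCOCCNC2CCCC2)cc1`) gives > 100000 nM, which is a limit of the assay and not a number. Compound 1 (`Nc1ccccc1COc1ccc(OCCOCCNC2CCCC2)cc1`) gives 14000 nM. Among the compounds with values here, the one measured step bears directly here, with carboxy in place of amino on an aromatic carbon: an at least 7.1-fold higher number from compound 1 to compound 2 (0.85 log units; beyond the scatter). Compound 3 (`Nc1ccc(COc2ccc(OCCOCCNC3CCCC3)cc2)cc1`) has 4-aminophenyl in place of 2-carboxyphenyl on a saturated chain carbon bound to an oxygen on an aromatic ring. An amino group therefore returns, so a change of similar size in the opposite direction, toward a lower number, is expected: an at least 6.6-fold lower number from compound 2 to compound 3 (0.82 log units; beyond the scatter). The estimate for compound 3 is 15000 nM, with an expected range of 4000 nM to 60000 nM.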

Compound 3, half-maximal inhibitory concentration: 31700 nM
Estimate against measurement, compound 3: 2.1-fold (0.32 log units) below; the range from low to high includes it.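

With 4-aminophenyl in place of 2-carboxyphenyl, the result is an at least 3.1-fold lower number from compound 2 to compound 3 (0.49 log units; beyond the scatter), so the lower number seen with an amino group does not depend on the amino group of compound 1 alone. The new comparison of the two amino compounds shows that the place of the amino group on the ring also matters, modestly: a 2.3-fold higher number from compound 1 to compound 3 (0.35 log units; beyond the scatter). Compound 2 has a limit, not a number, so its step gives only a bound: the limit of > 100000 nM in this assay, at which 1 of the 3 values shown sits.

On these data alone, whether a hydroxy group or a methylamino group on the same ring would give numbers like those of the amino compounds remains open.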